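Removing the Phenyl from the Core: An Estimate

The compounds below may be only part of what the source reports. "The series", "measured", "known", "first", "only" and "open" are said of these compounds alone.

Measured compounds:
Compound 1, `COC(=O)/C(=C\c1c(-c2ccccc2)[nH]c2ccccc12)S(=O)(=O)c1ccccc1`: 1000 nM
Compound 2, `O=C(/C(=C\c1c(-c2ccccc2)[nH]c2ccccc12)S(=O)(=O)c1ccccc1)c1ccccc1`: 3000 nM

Among the compounds with values here, in a functional assay on MT4 cells (Homo sapiens) for antiproliferative activity, read by MTT assay, with a stated time of 96 h (a higher number here means that more compound is needed for the effect, a lower number that less compound is needed), compound 1 gives 1000 nM, the lower of the two numbers measured so far. Within the data shown here, its only neighbour is compound 2, which in this assay gives 3000 nM; the step is a 3.0-fold higher number from compound 1 to compound 2 (0.48 log units; beyond the scatter), and it comes from a change at the carbonyl carbon, phenyl in place of methoxy, with the fused core left untouched.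

Compound 3, `COC(=O)/C(=C\c1c[nH]c2ccccc12)S(=O)(=O)c1ccccc1`, differs from compound 1 in a different place: hydrogen in place of phenyl on an aromatic carbon. Among the measured compounds shown here, no measured step touches this part of the structure, so there is nothing in the two numbers that speaks directly for or against it. For the measured compounds named here, the one known change, at the carbonyl carbon, moved the number by a modest amount, and a change on the core is taken here to be of roughly comparable size, with the risk that the core group matters more.

For compound 3 the number in this assay is estimated at 3000 nM, with a range of 800 nM to 12000 nM. The expected step is therefore a 3.0-fold higher number from compound 1 to compound 3 (0.48 log units; beyond the scatter).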

Compound 3, half-maximal effective concentration: > 100000 nM
Compound 3: a limit, no number (the forecaster's own chance of this, stated with the estimate: 10%); middle value at least 33-fold (1.52 log units) away from the limit.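

In this assay compound 3 carries a limit of the assay and not a number: the limit of > 100000 nM in this assay, at which 1 of the 3 values shown sits.

Taking away the phenyl on this aromatic carbon, next to the ring nitrogen, and leaving hydrogen gives an at least 100-fold higher number from compound 1 to compound 3 (2.00 log units; beyond the scatter) and that is a much larger step than a 3.0-fold higher number from compound 1 to compound 2 (0.48 log units; beyond the scatter) at the carbonyl carbon. The earlier pair both kept this phenyl, so they could say nothing about how much depends on it. Among these three compounds, this position is where a single change moves the number most, and the change at the carbonyl carbon now looks small beside it.

With only phenyl and hydrogen seen at this position, the compounds shown cannot tell whether it must be a phenyl or whether a methyl group, a chlorine atom or a pyridine ring would keep the number close to that of compound 1 at 1000 nM in this assay. The reason for the large step also stays open, as nothing shown here measures what the phenyl does.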